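The compounds below may be only part of what the source reports. "The series", "measured", "known", "first", "only" and "open" are said of these compounds alone.

In a functional assay on HepG2 cells (Homo sapiens) for antiproliferative activity, read by MTT assay, with a stated time of 72 h (on this read-out higher numbers stand for weaker inhibition and lower numbers for stronger inhibition), compound 1 `COc1cccc(N2C(=O)COc3ccc(-c4cnc5ccccc5c4)cc32)c1` gives 2080 nM while compound 3 `O=C1COc2ccc(-c3cnc4ccccc4c3)cc2N1c1ccc(F)cc1` gives 37200 nM and so holds the higher of the two true numbers. The gap between them is an 18-fold higher number from compound 1 to compound 3 (1.25 log units; beyond the scatter) and marks compound 3 as a weak inhibitor. Compound 2 `Cc1ccc(N2C(=O)COc3ccc(-c4cnc5ccccc5c4)cc32)cc1` gives > 40000 nM and this is a limit of the assay, not a number.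

Compound 4 `O=C1COc2ccc(-c3cnc4ccccc4c3)cc2N1` carries one change from compound 3: hydrogen in place of 4-fluorophenyl on an amide-type nitrogen in a ring which removes the group altogether.

Among the compounds with values here, no measured step does that. The closest are swaps of one aromatic group for another on this nitrogen. Besides the gap above, there is an at least 19-fold higher number from compound 1 to compound 2 (1.28 log units; beyond the scatter) and both are large, while an at least 1.0-fold lower number from compound 2 to compound 3 (0.03 log units; that floor lies within the scatter) stays within the scatter. Only compound 1 at 2080 nM reaches a low number, and compound 4 lacks its 3-methoxyphenyl, so no large fall is expected. The expected step is a 1.5-fold lower number from compound 3 to compound 4 (0.17 log units; within the scatter) and this lies within the scatter. Compound 4 is estimated at 25000 nM and is expected to fall from 6000 nM to 40000 nM in most measurements.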

Compound 4, half-maximal inhibitory concentration: 26300 nM
Compound 4: the middle estimate sits 1.1-fold (0.02 log units) below what was measured; measured number inside the range.
By their numbers in this assay, from the lowest: compound 1; then compounds 4 and 3 (each within the scatter of the next). At a limit, above all of these: compound 2.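

In this assay taking the 4-fluorophenyl off the amide-type nitrogen altogether gives a 1.4-fold lower number from compound 3 to compound 4 (0.15 log units; within the scatter) and so shows that this aromatic group adds nothing measurable here, which swaps of one aromatic group for another could not show. Taking off the 3-methoxyphenyl instead gives a 13-fold higher number from compound 1 to compound 4 (1.10 log units; beyond the scatter) and so, among the groups shown, only that one goes with a clearly lower number than plain hydrogen on this nitrogen. The step of an at least 1.5-fold lower number from compound 2 to compound 4 (0.18 log units; that floor lies within the scatter) is only a floor, set by a limit of the assay: the limit of > 40000 nM in this assay, at which 1 of the 4 values shown sits.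

From the compounds shown here alone, it remains open whether the methoxy group alone accounts for compound 1. Also open, going by these compounds, is how a non-aromatic group on this nitrogen, such as a methyl, a longer chain or a chain ending in an amine, would compare with hydrogen.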